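Extending the carbamate chain of a selenocyanate carbamate

The source may report more compounds than this note shows. Statements on the series, on what has been measured and on what is new or still open speak of the compounds shown alone.

Compound 1 `CCCOC(=O)Nc1ccc([Se]C#N)cc1` carries a selenocyanate group on a ring bearing a carbamate. In a functional assay on HTB-54 cells (Homo sapiens) for cytotoxicity, read by MTT assay, with a stated time of 72 h (on this read-out higher numbers stand for weaker inhibition of growth and lower numbers for stronger inhibition of growth), compound 1 gives 28900 nM. Two diselenide relatives were tested alongside it: compound 2 `O=C(Nc1ccc([Se][Se]c2ccc(NC(=O)Oc3ccccc3)cc2)cc1)Oc1ccccc1` gives 22700 nM, and compound 3 `C=CCOC(=O)Nc1ccc([Se][Se]c2ccc(NC(=O)OCC=C)cc2)cc1` gives 29800 nM. Compound 1 thus holds the second highest of the three numbers, but its gaps to compound 3 and to compound 2 both lie within the scatter, so the three cannot be ranked.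

Compound 4 `CCCCCCOC(=O)Nc1ccc([Se]C#N)cc1` differs from compound 1 by one change: propyl in place of hydrogen on a saturated chain carbon, three bonds along the chain from an oxygen next to a carbonyl group. Among the compounds with values here, no measured pair shows what such a change does here, so no step beyond the scatter is expected in either direction. The step from compound 1 to compound 4 is estimated at a 1.2-fold lower number from compound 1 to compound 4 (0.06 log units; within the scatter), and compound 4 is expected to give about 25000 nM, between 10000 nM and 60000 nM.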

Compound 4, concentration for 50% growth inhibition: 23600 nM
Compound 4: middle estimate off by 1.1-fold (0.03 log units), on the high side; the range from low to high includes it.
By their numbers in this assay, from the lowest: compounds 2, 4, 1 and 3 (each within the scatter of the next).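

In this assay, within the data shown here, propyl in place of hydrogen on a saturated chain carbon, three bonds along the chain from an oxygen next to a carbonyl group, gives the first measured step at this position (a 1.2-fold lower number from compound 1 to compound 4 (0.09 log units; within the scatter)). So in this assay the chain can grow from propyl to hexyl with no change that stands clear of the scatter. Nothing measured here offers an explanation for this result. Still open, as far as these compounds go, is what a longer chain such as octyl would do at this place, or a chain ending in an amine or a carboxylic acid.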